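Oxazolyl for Hydroxy on an Arylpiperazine Pyridine Amide

The source may hold more compounds than are shown below. What is called first, only, known or untested is meant among the compounds shown, and "the series" means these compounds.

This account follows two compounds sharing a pyridine amide linked through a three-carbon chain to an arylpiperazine, and another compound that has not yet been tested. Compound 1 `COc1ccccc1N1CCN(CCCNc2ccncc2C(=O)N(C(C)C)C(C)C)CC1` carries a methoxy group; in a functional assay on aorta for antagonist activity at Alpha-1D adrenergic receptor (Rattus norvegicus) (a higher number here means weaker binding, a lower number tighter binding), compound 1 gives 251 nM. Compound 2 `CN(C)C(=O)c1cccnc1NCCCN1CCN(c2ccccc2O)CC1` carries a hydroxy group and a smaller amide; in this assay compound 2 gives 63.1 nM, the lowest of the two numbers seen, with compound 1 standing beyond the scatter above it. The two compounds differ in more than one place, so only their two values can be compared.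

Compound 3 `CN(C)C(=O)c1cccnc1NCCCN1CCN(c2ccccc2-c2ncco2)CC1` is the next compound. Its change from compound 2 is 1,3-oxazol-2-yl in place of hydroxy on an aromatic carbon, on the aromatic carbon that sits ortho to a large group. Among the compounds with values here, no step between measured compounds tells how such a change behaves here, so the expectation rests on compound 2 alone. Compound 3 is expected to stay close to compound 2, with a step of a 1.3-fold higher number from compound 2 to compound 3 (0.10 log units; within the scatter) that may well lie within the scatter. The estimate for compound 3 in this assay is 80 nM, ranging from 20 nM to 320 nM.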

Compound 3, dissociation constant: 25.1 nM
Beside the measured number, compound 3's estimate is 3.2-fold (0.50 log units) above it; the measured number falls inside the stated range.
By their numbers in this assay, from the lowest: compound 3; then compound 2; then compound 1.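

In this assay, within the data shown here, putting 1,3-oxazol-2-yl in place of hydroxy gives a 2.5-fold lower number from compound 2 to compound 3 (0.40 log units; beyond the scatter) and is the first step here between measured compounds that differ in one place. It shows that this position, an aromatic carbon ortho to a large group, can take a group of 5 heavy atoms carrying a five-membered aromatic ring in place of a single oxygen, and that the number still falls beyond the scatter. It also shows that, for this pair, the hydrogen-bond donor of the hydroxy is not needed for the lower number, although nothing shown gives a reason for the change.

The compounds shown leave open whether the step belongs to the 1,3-oxazol-2-yl group in particular, since a single pair cannot separate it from what a phenyl ring, a 1,3-thiazol-2-yl group or an amine might do on the same carbon. They also leave open whether the same exchange would give a step of similar size on the larger amide of compound 1, or on a core with a longer chain to the piperazine.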